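The source may report more compounds than this note shows. Statements on the series, on what has been measured and on what is new or still open speak of the compounds shown alone.

Measured compounds:
- compound 1 `C[C@@H](NC(=O)c1ccc(C#Cc2ccccc2)cn1)C(C)(C)O` gives 60.9% in a functional assay on HEK293 cells for positive allosteric modulation of metabotropic glutamate receptor 5 (Rattus norvegicus), read by fluorescence and calcium flux; a lower number here means a smaller maximal response, a higher number a larger maximal response
- compound 2 `C[C@@H](NC(=O)c1ccc(C#Cc2ccc(F)cc2F)cn1)C(C)(C)O` gives 61.2%
- compound 3 `C[C@H](NC(=O)c1ccc(C#Cc2cccc(F)c2)cn1)C(C)(C)C` gives 70.8%

Compound 3 has the highest of the three numbers, yet both compound 2 and compound 1 lie within the scatter of it, so the three cannot be ordered. Within the data shown here, the one step between compounds that differ in a single place, a number 0.3 percentage points higher from compound 1 to compound 2 (within the scatter), concerns the group on the triple-bonded carbon and stays within the scatter.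

Compound 4 `CC(C)(CO)NC(=O)c1ccc(C#Cc2cccc(F)c2)cn1` is not yet measured. It differs from compound 3 as follows: 1-(hydroxymethyl)-1-methylethyl in place of 1,2,2-trimethylpropyl on an amide-type nitrogen. Among the measured compounds shown here, no measured step concerns the group on the amide-type nitrogen. Compounds 1 and 2, which carry a hydroxyl-bearing group there, show values that sit within the scatter of compound 3, so the three values give no sign that this part of the molecule moves the maximal response beyond the scatter. The step expected in this assay is therefore a number 5.8 percentage points lower from compound 3 to compound 4 (within the scatter), not beyond the scatter. Compound 4 is estimated at 65%, with a range from 50% to 80%.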

Compound 4, largest response reached (reported as efficacy), in percent of the reference or control that the assay uses: 60.9%
The estimate for compound 4 lay 4.1 percentage points above the measured number, within the range that was stated.
By their numbers in this assay, from the lowest: compounds 1, 4, 2 and 3 (each within the scatter of the next).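

Among these compounds, this is the first measured step at the group on the amide-type nitrogen: in this assay, 1-(hydroxymethyl)-1-methylethyl in place of 1,2,2-trimethylpropyl gives a number 9.9 percentage points lower from compound 3 to compound 4 (within the scatter) for the shared core. The exchange brings in a hydroxyl group and removes the defined stereocentre, yet the maximal response does not move beyond the scatter, so this position accepts the change with no readable effect in this assay. Nothing at hand explains this result.

On these data alone, whether an amine, a carboxylic acid or a longer chain on the amide-type nitrogen would move the maximal response beyond the scatter remains open. This single step also cannot separate the contribution of the hydroxyl group from that of the lost stereocentre.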